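The source may report more compounds than this note shows. Statements on the series, on what has been measured and on what is new or still open speak of the compounds shown alone.

Working notes on the series. Of the compounds shown here, three have been measured in a functional assay, with a stated time of 10 min; a lower number here means a stronger inhibitor, a higher number a weaker inhibitor. Compound 1 `CCOC(=O)c1cnn(-c2nc(-c3cccs3)c(C#N)c(=O)n2C)c1N` gives 109 ug/mL in this assay. Compound 2 `COc1ccc(-c2nc(NN)n(C)c(=O)c2C#N)cc1` gives 32 ug/mL in this assay, and compound 3 `Cn1c(NN)nc(-c2ccccc2O)c(C#N)c1=O` gives 30 ug/mL in this assay. Compound 1 therefore stands at the highest of the three numbers; the nearest to it is compound 2, and its number lies beyond the scatter below compound 1, as does that of compound 3. Going by the values given here, neither compound 2 nor compound 3 differs from compound 1 in only one place, so no single-change step is available from the measured set.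

Compound 4 `CCOC(=O)c1cnn(-c2nc(-c3cccc(OC)c3OC)c(C#N)c(=O)n2C)c1N` differs from compound 1 in one place: 2,3-dimethoxyphenyl in place of thiophen-2-yl on an aromatic carbon. Among the compounds with values here, no measured pair isolates this change, so the expectation for compound 4 rests on compound 1 alone together with the fact that compound 2 and compound 3 both lie at lower numbers.

Expectation: a small downward step, a 1.6-fold lower number from compound 1 to compound 4 (0.19 log units; within the scatter), is expected, of a size that may well stay within the scatter. Compound 4 is thus estimated at 70 ug/mL in this assay, with a range of 30 ug/mL to 160 ug/mL.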

Compound 4, half-maximal inhibitory concentration: 67 ug/mL
Compound 4: middle estimate off by 1.0-fold (0.02 log units), on the high side, within the range that was stated.
By their numbers in this assay, from the lowest: compounds 3 and 2 (each within the scatter of the next); then compounds 4 and 1 (each within the scatter of the next).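

Working notes on the series, continued. In this assay, the exchange of thiophen-2-yl for 2,3-dimethoxyphenyl on this aromatic carbon, ortho to a cyano group, gives a 1.6-fold lower number from compound 1 to compound 4 (0.21 log units; within the scatter), the first single-change step available in the series. At this position, then, a five-membered aromatic ring with 1 hetero atom and 5 heavy atoms can give way to a six-membered aromatic ring of carbon only with 10 heavy atoms, and the two methoxy groups come with it, without a step beyond the scatter. The pair offers no measurement that would account for this outcome.

Open, going by these compounds, is whether any group on this aromatic carbon moves the number beyond the scatter, for instance unsubstituted phenyl, a phenyl ring bearing a single methoxy group, or one carrying a carboxylic acid or a dimethylamino group. Also open, on these data alone, is how the two methoxy groups of 2,3-dimethoxyphenyl contribute individually, since this single step carries the ring exchange and both methoxy groups together.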